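The source may report more compounds than this note shows. Statements on the series, on what has been measured and on what is new or still open speak of the compounds shown alone.

Working notes on the series. In a functional assay on PC-3 cells (Homo sapiens) for inhibition (a higher number here means a weaker inhibitor, a lower number a stronger inhibitor), compound 1 `Cc1c(C(=O)N/N=C\c2c(O)cccc2Cl)oc2cccc(O)c12` gives 18700 nM, and compound 2 `Cc1c(C(=O)N/N=C\c2cc([N+](=O)[O-])ccc2O)oc2cccc(O)c12` gives 17100 nM; the two numbers sit within the scatter of each other, so no order is read between them. Compound 3 `Cc1c(C(=O)N/N=C\c2ccc(C(F)(F)F)cc2)oc2cccc(O)c12` reaches only a limit of this assay, >= 40000 nM, as noted in the limit of >= 40000 nM in this assay, at which 1 of the 3 values shown sits. Compound 4 `Cc1c(C(=O)N/N=C\c2ccccn2)oc2cccc(O)c12` is not yet measured; it differs from compound 1 by pyridin-2-yl in place of 2-chloro-6-hydroxyphenyl on a carbon with a double bond to nitrogen, the hydroxyl of the leaving group being lost. From compound 1 to compound 4 a step toward a weaker number is expected, a 1.9-fold higher number from compound 1 to compound 4 (0.27 log units; within the scatter), and a limit rather than a number is a fair possibility. Compound 4 is estimated in this assay at 35000 nM, likely between 15000 nM and 80000 nM.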

Compound 4, half-maximal inhibitory concentration: >= 40000 nM
Compound 4: a limit, no number; the forecaster's own chance of this, stated with the estimate: 50%; at least 1.1-fold (0.05 log units) between middle value and limit.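

Among the compounds shown here, the change to pyridin-2-yl in place of 2-chloro-6-hydroxyphenyl on a carbon with a double bond to nitrogen gives, in this assay, an at least 2.1-fold higher number from compound 1 to compound 4 (0.33 log units; beyond the scatter), the first step that can be read. Going by these compounds, the value of compound 4 is a limit, not a number, so the full size of this step stays unknown. A second compound now stands at the limit: the limit of >= 40000 nM in this assay, at which 2 of the 4 values shown sit.

The compounds shown leave open whether the hydroxyl or the chlorine of compound 1 matters more, as both leave in this one step. They also leave open what an amine or a carboxylic acid at this position would give.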